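The source may hold more compounds than are shown below. What is called first, only, known or untested is meant among the compounds shown, and "the series" means these compounds.

Measured so far:
compound 1, `CC[C@@H]1C(=O)N(C)c2cnc(-n3ccc4cc(C(N)=O)ccc43)nc2N1C1CCCC1` — a functional assay on Huh-7 cells (Homo sapiens) for antiproliferative activity, read by CCK-8 assay, with a stated time of 72 h; a lower number here means a stronger inhibitor of growth, a higher number a weaker inhibitor of growth: 3090 nM
compound 2, `CC[C@@H]1C(=O)N(C)c2cnc(-n3ccc4cc(C(=O)NC5CCCC5)ccc43)nc2N1C1CCCC1` — this assay: 259 nM
compound 3, `CCC1C(=O)N(C)c2cnc(-n3ccc4cc(C(=O)NC5CCCC5)ccc43)nc2N1c1ccn(C)n1` — this assay: "not active" (no number reported) (no number reported)

Compound 2 and compound 1 share a core and differ in one place only: hydrogen in place of cyclopentyl on an amide-type nitrogen. That change gives a 12-fold higher number from compound 2 to compound 1 (1.08 log units; beyond the scatter), a large loss of growth inhibition on going to the carbamoyl.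

Compound 3 carries a different core from compound 2; the difference between the two cores is not broken down here. In this assay compound 3 gives "not active" (no number reported), so no number stands against it.

Compound 4, `CCC1C(=O)N(C)c2cnc(-n3ccc4cc(C(N)=O)ccc43)nc2N1c1ccn(C)n1`, is to be measured in this assay. It stands to compound 3 as compound 1 stands to compound 2: hydrogen in place of cyclopentyl on an amide-type nitrogen. The place is the same word for word in both pairs, so this is the same kind of change, once on the core of compound 2 and once on the core of compound 3.

Compound 4 is expected to come out with no useful number, or at best a very high one, around 30000 nM, estimated between 8000 nM and 100000 nM. This rests on compound 3 giving "not active" (no number reported) and on the earlier step of a 12-fold higher number from compound 2 to compound 1 (1.08 log units; beyond the scatter), where the same change already cost a large part of the activity; the two matching cores only appear in this one pair, so the transfer remains an expectation.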

Compound 4, concentration for 50% growth inhibition: "not active" (no number reported)
No number was reported for compound 4, so the estimate cannot be set against anything.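

In this assay neither compound 3 nor compound 4 carries a number, so no step can be read between them. The compounds shown leave open whether going from cyclopentylcarbamoyl to carbamoyl on the core of compound 3 would match a 12-fold higher number from compound 2 to compound 1 (1.08 log units; beyond the scatter), and which part of that core's difference from the core of compound 2 accounts for the missing activity. No other data shown bear on this result.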